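Swapping a cyclohexyl ether for a fluorophenyl ether

The compounds below may be only part of what the source reports. "The series", "measured", "known", "first", "only" and "open" are said of these compounds alone.

Measured compounds:
- Compound 1 `FC(F)(F)Oc1ccc(Oc2ccnc(N3CCC(NC(=S)Nc4cccnc4)CC3)c2Cl)c(Cl)c1`: 11 nM
- Compound 2 `S=C(Nc1cccnc1)NC1CCN(c2cc(OC3CCCCC3)ccn2)CC1`: 3400 nM
- Compound 3 `S=C(Nc1cccnc1)NC1CCN(c2ncccc2Cl)CC1`: > 5000 nM

Three compounds sharing a thiourea-linked piperidine core were tested in an assay on membranes from brain for binding affinity to Lysophosphatidylserine lipase ABHD12 (Mus musculus), read by fluorescence, with a stated time of 20 min; a lower number here means a stronger inhibitor, a higher number a weaker inhibitor. Compound 1 gives 11 nM, the strongest result here. Compound 2 gives 3400 nM, the highest of the two numbers reported, far from compound 1 and beyond the usual scatter. For compound 3 the assay reports only a limit, (the limit of > 5000 nM in this assay, at which 1 of the 3 values shown sits), so no number is known for it.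

Compound 4 `Fc1ccc(Oc2ccnc(N3CCC(NC(=S)Nc4cccnc4)CC3)c2)cc1` has not yet been measured. It differs from compound 2 in one place: 4-fluorophenyl in place of cyclohexyl on an oxygen on an aromatic ring. For the measured compounds named here, no measured pair shows this exact change, so its size can only be estimated. Compound 1, which also carries an aromatic ring on that oxygen, gives 11 nM, a number well below that of compound 2, so a move of the same kind is expected for compound 4, a drop beyond the scatter, estimated as a 23-fold lower number from compound 2 to compound 4 (1.36 log units; beyond the scatter). Compound 4 is therefore estimated at 150 nM, with a plausible range from 30 nM to 800 nM.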

Compound 4, half-maximal inhibitory concentration: 1400 nM
Compound 4: the middle estimate sits 9.3-fold (0.97 log units) below what was measured; the measured number lies above the stated range.
By their numbers in this assay, from the lowest: compound 1; then compound 4; then compound 2. At a limit, above all of these: compound 3.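

In this assay the swap of cyclohexyl for 4-fluorophenyl on this oxygen can now be read on its own, and it gives a 2.4-fold lower number from compound 2 to compound 4 (0.39 log units; beyond the scatter) at this position. That step lies beyond the scatter but is modest, so an aromatic ring on the oxygen, taken alone, moves the number only a little. Compound 1 carries an aromatic ring there too, but it differs from compound 4 in more than one place, so its much lower number cannot be credited to that ring.

What sets the size of this step is not explained by anything shown here. Also open, from the compounds shown here alone, is how a plain phenyl without the fluorine, or a benzyl group, would read on the same oxygen.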